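Swapping the Ring on the Nitrogen of Compound 1

A few compounds are considered here, and "the series" means these few. Any claim that something is new, unique, unknown or untested is made for them only; others in the source may bear on it.

Compound 1 `Cc1cc(NC(=O)Cn2nnc(-c3ccccc3)n2)n(C2CCC(C)(C)CC2)n1` is the starting point. In an assay on HEK293 cells for activation of Kir3.1/Kir3.2 (Homo sapiens), read by thallium flux (a higher number here means a larger maximal response, a lower number a smaller maximal response), compound 1 gives only a limit, > 19%, not a number. Two related compounds have full numbers: compound 2 `CC1CC1c1cc(NC(=O)Cn2nnc(-c3ccccc3)n2)n(C2CCCCC2)n1` gives 78% in this assay, and compound 3 `O=C(Cn1nnc(-c2ccccc2)n1)Nc1cc(C2CC2)nn1C1CCCCC1` gives 45%. Within the data shown here, the one measured step, a number 33 percentage points lower from compound 2 to compound 3 (beyond the scatter), concerns a different place on the shared core and does not cover the change toward compound 4 `Cc1cc(NC(=O)Cn2nnc(-c3ccccc3)n2)n(CC2CCCCC2)n1`, which carries cyclohexylmethyl in place of 4,4-dimethylcyclohexyl on an aromatic nitrogen. Among the measured compounds shown here, with compound 1 known only as a limit of > 19% in this assay, at which 1 of the 3 values shown sits, and no measured step matching this change, no direction can be read from the data. Compound 4 is therefore expected near the middle of the observed range, with a step that the limit leaves unreadable from compound 1 to compound 4 that is itself only an estimate. The estimated value for compound 4 is 40%, between 15% and 75%.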

Compound 4, largest response reached (Emax), in percent of the reference or control that the assay uses: 77%
For compound 4 the middle estimate is 37 percentage points below the measured one; the whole stated range lies below it.
By their numbers in this assay, from the lowest: compound 3; then compounds 4 and 2 (each within the scatter of the next).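

Among these compounds, no step from compound 1 to compound 4 can be read, because compound 1 is known only as a limit: the limit of > 19% in this assay, at which 1 of the 4 values shown sits. The compounds shown leave open whether cyclohexylmethyl in place of 4,4-dimethylcyclohexyl raises or lowers the maximal response in this assay.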